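This account rests on a few compounds, and the source may have more. Where it says the series, first, only, none or still open, it means among the compounds named here.

Measured in a physicochemical assay for solubility; on this read-out higher numbers stand for higher solubility and lower numbers for lower solubility:
- Compound 1 `CC(C)C[C@@H]1NC(=O)[C@H](C(C)C)N(C)C(=O)[C@@H](CC(C)C)NC(=O)[C@@H](Cc2c[nH]c3ccccc23)NC(=O)[C@@H](C(c2ccccc2)c2ccccc2)NC1=O`: 1900 ug/mL
- Compound 2 `CC(C)C[C@@H]1NC(=O)[C@H](C(C)C)N(C)C(=O)[C@@H](CC(C)C)NC(=O)[C@@H](Cc2ccccc2)NC(=O)[C@@H]([C@H](OCc2ccccc2)c2ccccc2)NC1=O`: 5200 ug/mL

Compound 1 holds the lower of the two numbers, and the gap up to compound 2 lies beyond the usual scatter. Compound 3 `CC(C)C[C@@H]1NC(=O)[C@H](C(C)C)N(C)C(=O)[C@@H](CC(C)C)NC(=O)[C@@H](Cc2cscn2)NC(=O)[C@@H](C(c2ccccc2)c2ccccc2)NC1=O` differs from compound 1 in one place: 1,3-thiazol-4-yl in place of 1H-indol-3-yl on a saturated chain carbon bound to a saturated ring carbon. Among the compounds with values here, no measured pair of compounds differs in only one place, so the expectation is tentative. A modest rise is expected in this assay, and the estimated change is a 2.0-fold higher number from compound 1 to compound 3 (0.30 log units; within the scatter). For compound 3 the estimated value is 3800 ug/mL, with an expected range from 1600 ug/mL to 9000 ug/mL.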

Compound 3, solubility: 9500 ug/mL
Compound 3: middle estimate off by 2.5-fold (0.40 log units), on the low side; measured number outside the range, above it.
By their numbers in this assay, from the lowest: compound 1; then compounds 2 and 3 (each within the scatter of the next).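

In this assay, the first single-place step shows that this position, on a saturated chain carbon bound to a saturated ring carbon, tolerates a change with a clear effect: a 5.0-fold higher number from compound 1 to compound 3 (0.70 log units; beyond the scatter) follows when 1,3-thiazol-4-yl replaces 1H-indol-3-yl. The change swaps two aromatic rings for one and 9 heavy atoms for 5. Nothing measured here accounts for the step.

A single step cannot separate the lost donor, the added acceptors and the smaller group. Going by these compounds, how an amine or a carboxylic acid would read at this place remains open.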